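A few compounds are considered here, and "the series" means these few. Any claim that something is new, unique, unknown or untested is made for them only; others in the source may bear on it.

Working notes on the series.

Compound 1 `O=C(NCCCOc1ccc2nc(O)ccc2c1)N(C1CC1)[C@@H]1CCC[C@H]1O` is read in a functional assay on the whole organism for inhibition, with Rattus norvegicus as the target, at a dose of 30 mg/kg by the oral route (on this read-out lower numbers stand for less inhibition and higher numbers for more inhibition at the one dose given (going by the name of the read-out)), where compound 1 gives 23%. This is the highest of the three numbers in hand, though compound 2 `O=C(NCCCOc1ccc2nc(O)ccc2c1)N(C1CCCCC1)[C@H]1CCCC[C@@H]1O` sits close by, giving 18% in this assay; the gap between the two is within the usual scatter. Compound 3 `O=C(NCCCOc1ccc2nc(O)ccc2c1)N(C1CCCCCC1)[C@H]1CCCC[C@@H]1O` gives 11% in this assay, and its gap to compound 1 is beyond the scatter.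

For the measured compounds named here, the only measured step that changes one place is a number 7 percentage points lower from compound 2 to compound 3 (within the scatter), a change on an amide-type nitrogen that stays within the scatter.

The step to compound 4 `O=C(NCCCOc1ccc2nc(O)ccc2c1)N(C1CC1)[C@@H]1CCC[C@@H](O)C1` is 3-hydroxycyclohexyl in place of 2-hydroxycyclopentyl on an amide-type nitrogen. Going by the values given here, no measured step alters the hydroxy-bearing ring alone, so nothing in hand speaks directly to this change. Among the compounds with values here, compound 1 and compound 2 differ in both substituents on that nitrogen at once, so their two values show only that the combined change left the number within scatter. Within the data shown here, the one single-place step, the change from compound 2 to compound 3 on the same nitrogen, was small, so a small step, in either direction or none beyond the scatter, is the working expectation.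

Compound 4 is therefore estimated at 18%, with a range of 5% to 32%, which implies an expected step of a number 5 percentage points lower from compound 1 to compound 4 (within the scatter).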

Compound 4, a percentage reported as inhibition, in the whole organism at one dose (the size of the read-out at that dose, not a potency): 0%
Beside the measured number, compound 4's estimate is 18 percentage points above it, outside the stated range (below it).
By their numbers in this assay, from the lowest: compound 4; then compounds 3, 2 and 1 (each within the scatter of the next, the first and the last beyond it).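

In this assay, for the compounds shown here, the swap of 2-hydroxycyclopentyl for 3-hydroxycyclohexyl on the amide-type nitrogen gives the first single-place step beyond the scatter, a number 23 percentage points lower from compound 1 to compound 4 (beyond the scatter). Going by these compounds alone, the only earlier single-place step, a number 7 percentage points lower from compound 2 to compound 3 (within the scatter), concerned the other ring substituent on that nitrogen and stayed within the scatter, so this result shows that the read-out can respond clearly to a change in the hydroxy-bearing ring, with compound 4 at 0% at the one dose given. Nothing at hand explains the drop.

This single step changes ring size and the numbered place of the hydroxy together while the counted hydrogen-bond donors and acceptors stay the same, so the compounds shown cannot separate the contribution of the six-membered ring from that of the hydroxy placement. With the cyclopropyl group and the rest of compound 1 held constant, 3-hydroxycyclopentyl would test the placement alone, while 2-aminocyclopentyl would ask whether the hydroxy group itself can be exchanged for an amine on the original five-membered ring.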